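The source may hold more compounds than are shown below. What is called first, only, known or untested is meant among the compounds shown, and "the series" means these compounds.

Measured compounds:
compound 1, `COc1cc2c(Oc3ccc(NC(=O)c4nnn(-c5ccccc5)c4C)cc3F)ccnc2cc1OCCCN1CCCCC1`: 120 nM
compound 2, `COc1cc2c(Oc3ccc(NC(=O)c4nnn(-c5ccccc5C(F)(F)F)c4C)cc3F)ccnc2cc1OCCCN1CCCCC1`: 200 nM

In a functional assay on HT-29 cells (Homo sapiens) for cytotoxicity, read by MTT assay, with a stated time of 72 h (a lower number here means a stronger inhibitor, a higher number a weaker inhibitor), compound 1 gives 120 nM, the lowest of the two numbers. Within the data shown here, compound 2 gives 200 nM, and the only measured step, a 1.7-fold higher number from compound 1 to compound 2 (0.22 log units; within the scatter), concerns trifluoromethyl in place of hydrogen on an aromatic carbon. Compound 3, `COc1cc2c(Oc3ccc(NC(=O)c4nnn(-c5ccccc5)c4C)cc3F)ccnc2cc1OCCCN1CCC(C)CC1`, differs from compound 1 by methyl in place of hydrogen on a saturated ring carbon, reading piperidin-1-yl to 4-methylpiperidin-1-yl. Among the measured compounds shown here, no measured step touches this part of the molecule, so nothing indicates a move beyond the scatter; the expected step is no change at the digits printed from compound 1 to compound 3 (within the scatter). Compound 3 is therefore estimated at 120 nM, with a range of 50 nM to 300 nM.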

Compound 3, half-maximal inhibitory concentration: 140 nM
Beside the measured number, compound 3's estimate is 1.2-fold (0.07 log units) below it; low and high end bracket the measured number.
By their numbers in this assay, from the lowest: compounds 1, 3 and 2 (each within the scatter of the next).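

In this assay, among these compounds, the piperidin-1-yl group now has a measured step of its own, which the earlier compounds did not provide: 4-methylpiperidin-1-yl in place of piperidin-1-yl gives a 1.2-fold higher number from compound 1 to compound 3 (0.07 log units; within the scatter). A single methyl on this saturated ring carbon, three ring bonds from the ring nitrogen, therefore leaves the reading within the scatter. Nothing available bears on why the reading holds.

On these data alone, whether a hydroxyl, a carboxylic acid or a phenyl on this carbon would also stay within the scatter remains open. So does the outcome of replacing the whole ring with morpholin-4-yl.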